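A few compounds are considered here, and "the series" means these few. Any claim that something is new, unique, unknown or untested is made for them only; others in the source may bear on it.

Measured compounds:
compound 1, `CCCCCCNC(=O)Nc1nc2ccccc2s1`: > 10000 nM
compound 2, `O=C(NCCCCc1ccccc1)n1nnc2ccccc21`: 2.1 nM
compound 3, `O=C(NCCCCc1ccccc1)n1cnc2ccccc21`: 2.5 nM

In an assay on HEK293 cells for inhibition of acid ceramidase (Homo sapiens), read by fluorescence, with stated times of 30 min and 1 h (a higher number here means a weaker inhibitor, a lower number a stronger inhibitor), compound 1 gives > 10000 nM, which is a limit of the assay and not a number. Compound 1 therefore stands at the limit of > 10000 nM in this assay, at which 1 of the 3 values shown sits, and nothing more is known of where it lies. Compound 2 gives 2.1 nM and compound 3 gives 2.5 nM in this assay; these two sit within the usual scatter of each other. Compound 4, `O=C(NCCCCc1ccccc1)Nc1nc2ccccc2s1`, is not yet measured. It differs from compound 1 by phenyl in place of ethyl on a saturated chain carbon, four bonds along the chain from an amide-type nitrogen. Going by the values given here, no measured pair covers this change, and compounds 2 and 3 carry the phenyl on the chain but not the core of compound 1. The step from compound 1 to compound 4 in this assay is expected to be an at least 3.3-fold lower number from compound 1 to compound 4 (0.52 log units; beyond the scatter), a gain beyond the scatter. Compound 4 is expected to give 3000 nM, between 300 nM and 10000 nM.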

Compound 4, half-maximal inhibitory concentration: > 10000 nM
Compound 4: no number, only a limit; the forecaster's own chance of this, stated with the estimate: 40%; middle value at least 3.3-fold (0.52 log units) away from the limit.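

Compound 1 and compound 4 both stand at a limit of the assay, not at a number, so no step between them can be read: the limit of > 10000 nM in this assay, at which 2 of the 4 values shown sit.

The compounds shown leave open whether phenyl in place of ethyl changes the value at all in this assay.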